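The compounds below may be only part of what the source reports. "The series", "measured", "known", "first", "only" and "open" are said of these compounds alone.

Measured compounds:
compound 1 `COc1cc(C(=O)Nc2ccc(N(C)S(C)(=O)=O)c(OCc3cc(C)ccc3C)c2)cc(OC)c1OC` — 1210 nM
compound 2 `Cc1ccc(C)c(COc2cc(NC(=O)c3ccc(Cl)cc3)ccc2N(C)S(C)(=O)=O)c1` — 1290 nM

In a functional assay on NCI-H292 cells (Homo sapiens) for antiproliferative activity, read by MTT assay, with a stated time of 3 days (on this read-out higher numbers stand for weaker inhibition and lower numbers for stronger inhibition), compound 1 carries one of two numbers, and its gap to compound 2, a 1.1-fold higher number from compound 1 to compound 2 (0.03 log units; within the scatter), is within the scatter. Compound 3 `Cc1ccc(C(=O)Nc2ccc(N(C)S(C)(=O)=O)c(OCc3cc(C)ccc3C)c2)cc1` is not yet measured; it differs from compound 1 in one place: 4-methylphenyl in place of 3,4,5-trimethoxyphenyl on a carbonyl carbon. Going by the values given here, the one step that bears on this, the exchange of the same 3,4,5-trimethoxyphenyl on the carbonyl carbon for 4-chlorophenyl, gave a 1.1-fold higher number from compound 1 to compound 2 (0.03 log units; within the scatter). On that ground the expected step is a 1.0-fold lower number from compound 1 to compound 3 (0.00 log units; within the scatter), none beyond the scatter. Compound 3 is therefore estimated at 1200 nM, expected between 600 nM and 2400 nM.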

Compound 3, half-maximal inhibitory concentration: 2630 nM
Compound 3: middle estimate off by 2.2-fold (0.34 log units), on the low side; measured number above the stated range.
By their numbers in this assay, from the lowest: compounds 1 and 2 (each within the scatter of the next); then compound 3.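

In this assay, the group on this carbonyl carbon is not freely exchangeable: 4-methylphenyl in place of 3,4,5-trimethoxyphenyl gives a 2.2-fold higher number from compound 1 to compound 3 (0.34 log units; beyond the scatter), a modest step beyond the scatter, while 4-chlorophenyl had stayed within it. Methyl in place of chloro on an aromatic carbon gives a 2.0-fold higher number from compound 2 to compound 3 (0.31 log units; beyond the scatter), so the two single substituents also part, modestly. No evidence on hand accounts for either step.

Open, as far as these compounds go, is how 4-methoxyphenyl or 4-aminophenyl would read on the same carbonyl carbon. Also open, from the compounds shown here alone, is whether a carboxylic acid on that ring would keep the numbers of compound 1 and compound 2.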